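The source may hold more compounds than are shown below. What is called first, only, known or untested is meant among the compounds shown, and "the series" means these compounds.

Working notes on the series. The shared core carries a methylene-linked triazole bearing a thioether to a dichloroanilide and a saturated chain on the ring nitrogen. Compound 1 `CCOC(CCn1c(Cc2nn(C)c(=O)c3ccccc23)nnc1SCC(=O)Nc1ccc(Cl)cc1Cl)OCC` is the diethoxymethyl-terminated member. In an assay on NK92 cells for inhibition of interleukin-2 (Homo sapiens), read by AlphaScreen, with stated times of 30 min and 1 h (a lower number here means a stronger inhibitor, a higher number a weaker inhibitor), compound 1 gives > 30000 nM, which is a limit of the assay and not a number; it sits at the limit of > 30000 nM in this assay, at which 1 of the 2 values shown sits. Compound 2 `Cn1nc(Cc2nnc(SCCCCCCCC(=O)Nc3ccc(Cl)cc3Cl)n2CCC=O)c2ccccc2c1=O`, with a longer thioether chain and an aldehyde-terminated side chain, gives 960 nM in this assay as a measured number. For the measured compounds named here, no pair among the measured compounds differs in a single place, so no step within the data is available.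

Compound 3 `Cn1nc(Cc2nnc(SCC(=O)Nc3ccc(Cl)cc3Cl)n2CCC(=O)O)c2ccccc2c1=O` is the next member to be measured. The change from compound 1 is carboxy in place of diethoxymethyl on a saturated chain carbon, two bonds along the chain from an aromatic nitrogen. Because compound 1 gives > 30000 nM only as a limit, the step can only be read as a gain or as nothing beyond the scatter; a moderate gain is expected, an at least 3.0-fold lower number from compound 1 to compound 3 (0.47 log units; beyond the scatter), with compound 3 estimated at 10000 nM, range 2000 nM to 40000 nM, and a real chance that only a limit is reported.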

Compound 3, half-maximal inhibitory concentration: > 30000 nM
Compound 3 gave a limit, no number; the forecaster's own chance of this, stated with the estimate: 40%; middle value at least 3.0-fold (0.47 log units) from the limit.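

No new step can be read: compound 1 and compound 3 both end at a limit of this assay, not at a number: the limit of > 30000 nM in this assay, at which 2 of the 3 values shown sit.

The compounds shown leave open whether carboxy in place of diethoxymethyl changes the inhibition at all, and how far either compound lies from that limit.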